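A methoxycarbonyl added to the chain of compound 2

The source may hold more compounds than are shown below. What is called first, only, known or untested is meant among the compounds shown, and "the series" means these compounds.

In a functional assay on HepG2 cells (Homo sapiens) for inhibition, read by crystal violet staining, with a stated time of 48 h (a higher number here means a weaker inhibitor, a lower number a stronger inhibitor), compound 1 `COC(=O)CCn1sc(Cl)cc1=O` gives 24000 nM as a measured value. Compound 2 `CCn1c(=O)cc(Cl)[s+]1[O-]` reaches only a limit of the assay, and compound 2 is reported as > 100000 nM without an exact number. Compound 3 `COC(=O)CCn1c(=O)cc(Cl)[s+]1[O-]` differs from compound 2 by one change, methoxycarbonyl in place of hydrogen on a saturated chain carbon, two bonds along the chain from an aromatic nitrogen in all, which places methoxycarbonyl in place of hydrogen on a saturated chain carbon, two bonds along the chain from an aromatic nitrogen. For the measured compounds named here, no measured step guides this change. A methoxycarbonyl also stands in compound 1, which reads 24000 nM in this assay as a number. On that ground a modest move towards stronger inhibition is expected, though its size stays uncertain with a limit as the starting point. The expected change is an at least 2.2-fold lower number from compound 2 to compound 3 (0.34 log units; beyond the scatter) in this estimate. The estimated value for compound 3 is 45000 nM with an expected range of 12000 nM to 100000 nM in the same assay.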

Compound 3, half-maximal inhibitory concentration: > 100000 nM
Compound 3 was reported as a limit (the forecaster's own chance of this, stated with the estimate: 30%); middle value at least 2.2-fold (0.34 log units) away from the limit.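

Compound 2 and compound 3 are both reported only as limits in this assay, so no step between them can be read: the limit of > 100000 nM in this assay, at which 2 of the 3 values shown sit.

The compounds shown leave open whether methoxycarbonyl in place of hydrogen on a saturated chain carbon, two bonds along the chain from an aromatic nitrogen, changes inhibition in this assay at all.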